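Moving the sulfur substituent from 4-methylphenyl to 4-methylbenzyl

A few compounds are considered here, and "the series" means these few. Any claim that something is new, unique, unknown or untested is made for them only; others in the source may bear on it.

- Compound 1 `COc1ccc(/C=C(/Sc2ccc(C)cc2)C(=O)c2ccc(Br)cc2)cc1` gives 50000 nM
- Compound 2 `Cc1ccc(S/C(=C/c2ccc(Cl)cc2)C(=O)c2ccc(Br)cc2)cc1` gives 10000 nM
- Compound 3 `CSc1ccc(/C=C(/Sc2ccc(C)cc2)C(=O)c2ccc(Br)cc2)cc1` gives 50000 nM

In a functional assay on DU-145 cells (Homo sapiens) for inhibition, read by trypan blue exclusion, with a stated time of 96 h (a higher number here means a weaker inhibitor of growth, a lower number a stronger inhibitor of growth), compound 3 stands level with compound 1, and together they hold the highest of the three numbers. The next compound to be tested is compound 4 `CSc1ccc(/C=C(/SCc2ccc(C)cc2)C(=O)c2ccc(Br)cc2)cc1` and it differs from compound 3 in one place: 4-methylbenzyl in place of 4-methylphenyl on a sulfur with 4-methylbenzyl in place of 4-methylphenyl on a sulfur.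

Going by the values given here, none of the measured steps changes the group on that sulfur, so they bear on this change only indirectly. They show how far values move in this small set: a 5.0-fold lower number from compound 1 to compound 2 (0.70 log units; beyond the scatter) and a 5.0-fold higher number from compound 2 to compound 3 (0.70 log units; beyond the scatter) are modest, while no change at the digits printed from compound 1 to compound 3 (within the scatter) stays within the scatter. Compound 3 already gives 50000 nM at the top of the numbers seen, so a modest move to a lower number is expected, though the direction remains uncertain. An estimated step of a 2.5-fold lower number from compound 3 to compound 4 (0.40 log units; beyond the scatter) is expected here. The estimate for compound 4 is 20000 nM within an expected range of 4000 nM to 60000 nM in this measurement.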

Compound 4, concentration for 50% growth inhibition: > 100000 nM
Compound 4 gave a limit, no number (the forecaster's own chance of this, stated with the estimate: 15%); at least 5.0-fold (0.69 log units) between middle value and limit.
By their numbers in this assay, from the lowest: compound 2; then compounds 1 and 3 (each within the scatter of the next). At a limit, above all of these: compound 4.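

In this assay compound 4 gives > 100000 nM, which is a limit of the assay and not a number. On these data alone, the step on the sulfur reads an at least 2.0-fold higher number from compound 3 to compound 4 (0.30 log units; that floor lies within the scatter), and since this is only a floor, the real size of the step remains unknown. This is the only change on that sulfur among the compounds shown, and swapping 4-methylphenyl for 4-methylbenzyl gave no lower number, leaving the reading at the end of the assay's range: the limit of > 100000 nM in this assay, at which 1 of the 4 values shown sits.

As far as these compounds go, how far compound 4 lies past compound 3 stays open, as does whether the same swap would give a lower number with the chloro group of compound 2 in place of methylsulfanyl. Also open, from the compounds shown here alone, is how a plain methyl, a longer 2-phenylethyl chain or a chain ending in an amine would read on that sulfur.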